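Swapping a Nitrile for Chlorine on the Urea Aryl Ring

This account rests on a few compounds, and the source may have more. Where it says the series, first, only, none or still open, it means among the compounds named here.

Compound 1, `CC1(C)CN(NC(=S)Nc2ccc(C#N)cc2)c2cc(Cl)ccc2O1`, in a functional assay on thoracic aorta (Rattus norvegicus); on this read-out lower numbers stand for an effect already at smaller amounts and higher numbers for an effect only at larger amounts of compound: > 30000 nM, a limit of the assay rather than a number.
Compound 2, `CC1(C)CN(NC(=S)Nc2cccc(Cl)c2)c2cc(Cl)ccc2O1`, in this assay: > 30000 nM, also only a limit.
Compound 3, `CC1(C)CN(NC(=O)Nc2cccc(C#N)c2)c2cc(Cl)ccc2O1`, in this assay: 1900 nM.

Going by the values given here, compound 3 is thus the only compound with a measured number; compound 1 sits at the limit of > 30000 nM in this assay, at which 2 of the 3 values shown sit, as does compound 2. Among the compounds with values here, the single step between measured compounds, a step that the two limits leave unreadable from compound 1 to compound 2, cannot be read. Compound 4, `CC1(C)CN(NC(=O)Nc2ccc(Cl)cc2)c2cc(Cl)ccc2O1`, differs from compound 3 by 4-chlorophenyl in place of 3-cyanophenyl on an amide-type nitrogen. Within the data shown here, no measured step resembles this change, and compounds 1 and 2 differ from compound 3 in more than one place, so they give no guidance. The change is therefore expected to be modest, and compound 4 is estimated at 3000 nM, with a range of 800 nM to 15000 nM, meaning an expected step of a 1.6-fold higher number from compound 3 to compound 4 (0.20 log units; within the scatter).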

Compound 4, half-maximal effective concentration: 13300 nM
The estimate for compound 4 lay 4.4-fold (0.65 log units) below the measured number; measured number inside the range.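

Going by these compounds alone, this is the first readable change at the aryl group on the amide-type nitrogen: in this assay, the swap gives a 7.0-fold higher number from compound 3 to compound 4 (0.85 log units; beyond the scatter). What sits at this place therefore matters to the read-out, at least for this pair. Nothing shown gives a measured cause for the step.

Compounds 3 and 4 cannot separate the exchange of nitrile for chlorine from the difference between the 3- and 4-substituted rings, since 3-cyanophenyl and 4-chlorophenyl differ in both. Going by these compounds, how a phenyl ring carrying an amine or a carboxylic acid would read here also stays open.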